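Iodo Gives Way to Isopropyl in Compound 4

The source may hold more compounds than are shown below. What is called first, only, known or untested is meant among the compounds shown, and "the series" means these compounds.

Compound 3 `O=C(Nc1ccncc1)Nc1ccc(I)cc1` sits at the edge of what a functional assay on the whole organism with Mus musculus as the target, in the maximal electroshock model, with a stated time of 30 min (on this read-out higher numbers stand for an effect only at larger amounts of compound and lower numbers for an effect already at smaller amounts), can report: there compound 3 shows > 300 mg/kg, which is a limit of the assay and not a number. Compound 1 `O=C(Nc1ccncc1)Nc1ccccc1OCc1ccccc1` is in the same position, showing > 300 mg/kg, again a limit, so that the limit of > 300 mg/kg in this assay, at which 2 of the 3 values shown sit, covers two of the three values. Among the measured compounds shown here, only compound 2 `CN(C)c1ccccc1NC(=O)Nc1ccncc1` gives a number, 100 mg/kg, and the sole measured step is an at least 3.0-fold lower number from compound 1 to compound 2 (0.47 log units; beyond the scatter). Compound 4 `CC(C)c1ccc(NC(=O)Nc2ccncc2)cc1` differs from compound 3 by isopropyl in place of iodo on an aromatic carbon. For the measured compounds named here, no measured step involves a change of this kind, so none bears on it directly. Compound 4 is therefore expected to move little, with an expected step of a number no higher from compound 3 to compound 4 (the limit leaves the size open). The estimate for compound 4 is 300 mg/kg, between 100 mg/kg and 600 mg/kg.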

Compound 4, minimum effective dose: > 300 mg/kg
Compound 4: only a limit was reported; the forecaster's own chance of this, stated with the estimate: 60%; the middle value sits exactly at the limit.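

Compound 3 and compound 4 both sit at a limit of the assay, so no step between them can be read: the limit of > 300 mg/kg in this assay, at which 3 of the 4 values shown sit.

The compounds shown leave open whether isopropyl in place of iodo changes the minimum effective dose at all, and in which direction.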